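Replacing the 4-methoxyphenyl group of compound 1

A few compounds are considered here, and "the series" means these few. Any claim that something is new, unique, unknown or untested is made for them only; others in the source may bear on it.

Among the compounds with values here, in a functional assay on HeLa cells (Homo sapiens) for inhibition, read by MTT assay, with a stated time of 72 h (a lower number here means a stronger inhibitor, a higher number a weaker inhibitor), compound 1 (`COc1ccc(C(=O)/C=C/c2cc(OC)c(OC)cc2OC)cc1`) gives 37600 nM, the only numeric value so far. Compound 2 (`COc1cc(OC)c(OC)cc1/C=C/C(=O)c1ccc(-c2c[nH]cn2)cc1`) gives only a limit of the assay, > 150000 nM. Within the data shown here, the single measured step, with 1H-imidazol-4-yl in place of methoxy on an aromatic carbon, is an at least 3.9-fold higher number from compound 1 to compound 2 (0.60 log units; beyond the scatter). Compound 3 (`COc1cc(OC)c(OC)cc1/C=C/C(=O)c1cc(O)ccc1O`) has 2,5-dihydroxyphenyl in place of 4-methoxyphenyl on a carbonyl carbon. The measured step also alters the 4-methoxyphenyl group, so it bears on this change, but its entering group is different and its size is known only as a limit. It therefore gives no firm direction here. A modest step toward a lower number is tentatively expected, and the range allows for no change. The estimated step is a 2.5-fold lower number from compound 1 to compound 3 (0.40 log units; beyond the scatter). Compound 3 is expected at 15000 nM, within an estimated range of 4000 nM to 60000 nM.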

Compound 3, half-maximal inhibitory concentration: > 150000 nM
Compound 3: a limit, no number; the forecaster's own chance of this, stated with the estimate: 10%; middle value at least 10-fold (1.00 log units) away from the limit.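

In this assay, 2,5-dihydroxyphenyl in place of 4-methoxyphenyl on a carbonyl carbon gives an at least 3.9-fold higher number from compound 1 to compound 3 (0.60 log units; beyond the scatter). This replacement keeps a six-membered aromatic ring of carbon only and the same count of heavy atoms, yet it also moves to a higher number, so the rise seen so far is not confined to the 1H-imidazol-4-yl change of compound 2. Compound 3 ends at a limit of the assay and not at a number, so the true size of this change stays unknown: the limit of > 150000 nM in this assay, at which 2 of the 3 values shown sit.

Still open, from the compounds shown here alone, is whether any replacement of the 4-methoxyphenyl group gives a lower number than compound 1. The compounds shown also leave open how a single hydroxy group, as in 4-hydroxyphenyl, or an amine or a carboxylic acid in place of methoxy would read.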